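Adding a Second Bromo to Compound 2

The source may hold more compounds than are shown below. What is called first, only, known or untested is meant among the compounds shown, and "the series" means these compounds.

In a functional assay on A549 cells (Homo sapiens) for antiproliferative activity, read by sulforhodamine B assay, with a stated time of 72 h (a lower number here means a stronger inhibitor, a higher number a weaker inhibitor), compound 1 `O=C(/C=C/c1csc2ccccc12)c1ccccc1O` gives 5300 nM and compound 2 `O=C(/C=C/c1csc2ccccc12)c1cc(Br)ccc1O` gives 660 nM. Within the data shown here, compound 2 therefore holds the lower of the two numbers measured so far, which makes it the stronger inhibitor of this pair.

The next structure, compound 3 `O=C(/C=C/c1csc2ccccc12)c1cc(Br)cc(Br)c1O`, changes compound 2 in one place: bromo in place of hydrogen on an aromatic carbon. A bromo takes the place of hydrogen on an aromatic carbon, ortho to a hydroxy group and meta to the bromo group already present.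

Among the measured compounds shown here, only one measured step bears on this change. The same kind of swap gave an 8.0-fold lower number from compound 1 to compound 2 (0.90 log units; beyond the scatter), a modest step that lies beyond the usual scatter. That is thin evidence, since a single step cannot show whether a second bromo at another place would repeat the gain. The sensible expectation is a smaller move in the same direction, and it may not clear the scatter at all. The estimated change in this assay is a 1.7-fold lower number from compound 2 to compound 3 (0.22 log units; within the scatter). For compound 3 the expected value is 400 nM, with an estimated range of 130 nM to 1200 nM.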

Compound 3, half-maximal inhibitory concentration: 4200 nM
Estimate against measurement, compound 3: 11-fold (1.02 log units) below, and the stated range ends below it.
By their numbers in this assay, from the lowest: compound 2; then compounds 3 and 1 (each within the scatter of the next).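

In this assay, the second bromo reverses the direction seen with the first: the swap that gave an 8.0-fold lower number from compound 1 to compound 2 (0.90 log units; beyond the scatter) now gives a 6.4-fold higher number from compound 2 to compound 3 (0.80 log units; beyond the scatter) at this new place. The same exchange of hydrogen for bromo on an aromatic carbon therefore has no fixed effect in these compounds, and the outcome changes with where the bromo sits. At this place, ortho to a hydroxy group and meta to a bromo group, the added bromo gives a weaker inhibitor than compound 2, and nothing measured here accounts for that loss.

The compounds shown leave open whether the loss belongs to bromo itself or to any group at this place, a question that a chloro, a fluoro, a methyl or a methoxy group there could help to answer. They also leave open how an amine or a carboxylic acid at this same place would compare with the hydrogen of compound 2, so one bromo step describes only a single substitution at this place.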